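From One Ethoxy Group to Two

This account rests on a few compounds, and the source may have more. Where it says the series, first, only, none or still open, it means among the compounds named here.

In a functional assay on KM12 cells (Homo sapiens) for antiproliferative activity (a lower number here means a stronger inhibitor of growth, a higher number a weaker inhibitor of growth), compound 1 (`COc1ccc(-c2nc3cc(F)ccc3s2)cc1`) gives 24600 nM, compound 2 (`COc1ccc(-c2nc3cc(F)ccc3s2)cc1OC`) gives 290 nM, and compound 3 (`CCOc1cc(-c2nc3cc(F)ccc3s2)ccc1OC`) gives 5420 nM. Compound 3 therefore holds the middle place among the three, with the second highest number.

The move to compound 4 (`CCOc1ccc(-c2nc3cc(F)ccc3s2)cc1OCC`) is methyl in place of hydrogen on a saturated chain carbon bound to an oxygen on an aromatic ring, so that methoxy becomes ethoxy. Going by the values given here, the closest precedent is the same kind of change, a 19-fold higher number from compound 2 to compound 3 (1.27 log units; beyond the scatter). Two further steps show methoxy gaining far more than ethoxy when replacing hydrogen on an aromatic carbon: an 85-fold lower number from compound 1 to compound 2 (1.93 log units; beyond the scatter), against a 4.5-fold lower number from compound 1 to compound 3 (0.66 log units; beyond the scatter). Among the compounds with values here, all of these favour methoxy over ethoxy, but only one direct precedent exists, and it started from a much lower number. A moderate rise is therefore expected, smaller than that precedent, with an estimated 2.8-fold higher number from compound 3 to compound 4 (0.44 log units; beyond the scatter). Compound 4 is estimated at 15000 nM, within an expected range of 3000 nM to 60000 nM.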

Compound 4, concentration for 50% growth inhibition: 38500 nM
Compound 4: the middle estimate sits 2.6-fold (0.41 log units) below what was measured; measured number inside the range.
By their numbers in this assay, from the lowest: compound 2; then compound 3; then compounds 1 and 4 (each within the scatter of the next).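

In this assay the change from methoxy to ethoxy gives a 7.1-fold higher number from compound 3 to compound 4 (0.85 log units; beyond the scatter) and so repeats, on the other methoxy group, the direction of a 19-fold higher number from compound 2 to compound 3 (1.27 log units; beyond the scatter) from a starting number that was already far higher. Methoxy to ethoxy therefore raises the number both times it occurs among these compounds, and neither step goes against this, although the first is large and the second modest. Nothing measured here explains the rise at either group.

As far as these compounds go, what remains open is whether the number keeps rising with a longer chain such as propoxy on the same oxygen. It is also unclear how an amine or a hydroxyl group in place of either ethoxy would behave on the shared core.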